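Working notes: methyl removal on the core of compound 2

The source may hold more compounds than are shown below. What is called first, only, known or untested is meant among the compounds shown, and "the series" means these compounds.

Measured so far in a functional assay on MCF7 cells (Homo sapiens) for cytotoxicity, read by MTT assay, with a stated time of 24 h, tested at 50 uM; on this read-out lower numbers stand for a stronger effect and higher numbers for a weaker effect at the one concentration tested:
compound 1, `Cc1nc2c(Br)c(Br)c(Br)c(Br)c2n1CC#N` — 11%
compound 2, `Cc1nc2c(Br)c(Br)c(Br)c(Br)c2n1CCCCC#N` — 42%

Among the measured compounds shown here, compound 2 stands highest of the two numbers; the only other number is that of compound 1, reached by the step of a number 31 percentage points higher from compound 1 to compound 2 (beyond the scatter). That step is the sole measured one, and it concerns the chain on the ring nitrogen, not the ring carbons.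

Compound 3, `N#CCCCCn1cnc2c(Br)c(Br)c(Br)c(Br)c21`, keeps the 4-cyanobutyl chain of compound 2 and differs from it by hydrogen in place of methyl on an aromatic carbon. For the measured compounds named here, no measured step touches this aromatic carbon, so nothing bears directly on the change. With only an unrelated step to go by, the step of no change at the digits printed from compound 2 to compound 3 (within the scatter) is expected to stay within the scatter. Compound 3 is therefore estimated at 42%, with a range from 25% to 60%.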

Compound 3, a percentage reported as activity, at one concentration (the size of the read-out at that concentration, not a potency): 18%
Estimate against measurement, compound 3: 24 percentage points above; measured number below the stated range.
By their numbers in this assay, from the lowest: compounds 1 and 3 (each within the scatter of the next); then compound 2.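

In this assay, the aromatic carbon between two ring nitrogen atoms proves to be a position that counts: hydrogen in place of methyl gives a number 24 percentage points lower from compound 2 to compound 3 (beyond the scatter). The read-out therefore depends on this ring carbon as well as on the chain on the ring nitrogen, and with the 4-cyanobutyl group kept, the methyl goes with the weaker effect at the one concentration tested. The data at hand offer no explanation for this step.

From the compounds shown here alone, it remains open whether hydrogen in place of methyl gives a step of similar size with the chain of compound 1. Also open, going by these compounds, is how an ethyl group or an amine on this aromatic carbon would compare with hydrogen and methyl in this assay.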